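The source may report more compounds than this note shows. Statements on the series, on what has been measured and on what is new or still open speak of the compounds shown alone.

Working notes on the series. Going by the values given here, compound 1 `Cn1c(-c2ccc(O)cc2)nc2c(NC3CCCC3)ncnc21` gives 521 nM in an assay on CHO cells for displacement of a labelled ligand from adenosine receptor A3 (Homo sapiens), read by scintillation counting, with a stated time of 3 h (a higher number here means a weaker inhibitor, a lower number a stronger inhibitor), the second highest of the three numbers so far. Compound 2 `CCn1c(-c2ccccc2)nc2c(NC3CCCC3)ncnc21` gives 354 nM, which lies within the usual scatter of the value for compound 1. Among the compounds with values here, compound 3 `CCCn1c(-c2ccccc2)nc2c(NC3CCOC3)ncnc21` gives 2810 nM, a higher number than compound 1 by more than the scatter; compound 3 also differs from compound 1 in more than one place, so no single step is read from that pair.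

Compound 4 `Cn1c(-c2ccccc2Cl)nc2c(NC3CCCC3)ncnc21` is not yet measured. It differs from compound 1 in one place: 2-chlorophenyl in place of 4-hydroxyphenyl on an aromatic carbon. Within the data shown here, no measured pair in the set isolates this change, so the expected step from compound 1 to compound 4 in this assay is a 1.2-fold higher number from compound 1 to compound 4 (0.06 log units; within the scatter), with no direction beyond the scatter firmly expected. Compound 4 is accordingly estimated at 600 nM, within 150 nM to 2500 nM.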

Compound 4, inhibition constant: 720 nM
For compound 4 the middle estimate is 1.2-fold (0.08 log units) below the measured one; low and high end bracket the measured number.
By their numbers in this assay, from the lowest: compounds 2, 1 and 4 (each within the scatter of the next, the first and the last beyond it); then compound 3.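

In this assay, 2-chlorophenyl in place of 4-hydroxyphenyl on the aromatic carbon between two ring nitrogen atoms gives a 1.4-fold higher number from compound 1 to compound 4 (0.14 log units; within the scatter), the first step read at this position. The entering group has 0 hydrogen-bond donors and 0 hydrogen-bond acceptors against 1 of each in the leaving group, yet the pair stays within the scatter. No measurement on hand explains this result.

Going by these compounds alone, the single step changes both the substituent and its place on the phenyl ring, so the two cannot be separated. On these data alone, whether an aminophenyl or a carboxyphenyl group at this position would also stay within the scatter remains open.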